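Sulfonamide series: isopropylamino in place of isopropylcarbonylamino

A few compounds are considered here, and "the series" means these few. Any claim that something is new, unique, unknown or untested is made for them only; others in the source may bear on it.

Measured so far in an assay on VSM-A10 cells for antagonist activity at Endothelin-1 receptor (Rattus norvegicus); on this read-out higher numbers stand for weaker inhibition and lower numbers for stronger inhibition:
compound 1, `Cc1noc(NS(=O)(=O)c2cccc3c(NC(=O)C(C)C)cccc23)c1C`: 880 nM
compound 2, `Cc1noc(N(CC(=O)O)S(=O)(=O)c2ccc(N)cc2)c1C`: > 32000 nM
compound 3, `Cc1noc(NS(=O)(=O)c2cccc([N+](=O)[O-])c2)c1C`: 7800 nM

Of the two numbers shown, compound 1 carries the lower one, and the gap to compound 3 lies beyond the scatter of this assay. For compound 2 the value is a limit of this assay, not a number, as the line the limit of > 32000 nM in this assay, at which 1 of the 3 values shown sits, records. Within the data shown here, no two of the measured compounds differ in a single place, so no measured step is available to lean on.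

Compound 4, `Cc1noc(NS(=O)(=O)c2cccc3c(NC(C)C)cccc23)c1C`, differs from compound 1 in one place: isopropyl in place of isopropylcarbonyl on a nitrogen on an aromatic ring. Cut one bond further out, the change reads (isopropylcarbonyl)amino to isopropylamino. With no measured step of this kind in the set, the direction is open; a weakening step, of modest size and not certainly beyond the scatter, is expected in this assay for compound 4, as a 2.3-fold higher number from compound 1 to compound 4 (0.36 log units; beyond the scatter). Compound 4 is therefore estimated at 2000 nM, in the range 400 nM to 10000 nM.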

Compound 4, half-maximal inhibitory concentration: 20 nM
The estimate for compound 4 lay 100-fold (2.00 log units) above the measured number, outside the stated range (below it).
By their numbers in this assay, from the lowest: compound 4; then compound 1; then compound 3. At a limit, above all of these: compound 2.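

In this assay the step is a 44-fold lower number from compound 1 to compound 4 (1.64 log units; beyond the scatter) on replacing isopropylcarbonyl with isopropyl on the nitrogen on the aromatic ring, so the carbonyl is not needed for inhibition in this pair, and the number is lower without it. Among these compounds, as the only single-place step measured, it shows that the group on this nitrogen can move the number by a large amount on the core of compound 1. Nothing among the compounds shown accounts for the size of this step.

Open, from the compounds shown here alone, is whether the branched isopropyl matters or only the absence of the carbonyl, which the plain amine, ethylamino or a longer chain such as n-butylamino on this nitrogen would separate. Also open, going by these compounds, is whether the same exchange gives a step of this size on a different core.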